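Series notes: cytotoxicity, compounds 1 to 4

The compounds below may be only part of what the source reports. "The series", "measured", "known", "first", "only" and "open" are said of these compounds alone.

Measured so far:
compound 1 `C/C(=N\NC(=O)COc1cccc2ccccc12)c1ccc(O)cc1`: 20 ug/mL
compound 2 `C/C(=N\NC(=O)COc1cccc2ccccc12)c1ccccc1O`: 20 ug/mL
compound 3 `C/C(=N\NC(=O)COc1cccc2ccccc12)c1ccc(Br)cc1`: 20 ug/mL

In an ADME assay on HEL cells (Homo sapiens) for cytotoxicity (a lower number here means that less compound is tolerated, a higher number that more compound is tolerated), the three measured values lie level with one another: no change at the digits printed from compound 1 to compound 3 (within the scatter); no change at the digits printed from compound 2 to compound 3 (within the scatter); and likewise no change at the digits printed from compound 1 to compound 2 (within the scatter). Going by the values given here, every measured step so far exchanges the aromatic group on the carbon with a double bond to nitrogen, or its substituent, and none moved the read-out beyond the scatter.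

Compound 4 `C/C(=N\NC(=O)COc1cccc2ccccc12)c1cccc([N+](=O)[O-])c1` differs from compound 3 as follows: 3-nitrophenyl in place of 4-bromophenyl on a carbon with a double bond to nitrogen. Among the compounds with values here, no measured compound carries a nitro group, so no step addresses this substituent directly; the three steps that do bear on it all swap groups at this same position and were flat. The expectation is therefore no step beyond the scatter, no change at the digits printed from compound 3 to compound 4 (within the scatter). Compound 4 is estimated at 20 ug/mL, with a range of 10 ug/mL to 40 ug/mL.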

Compound 4, minimum cytotoxic concentration in the HEL assay: 20 ug/mL
Estimate against measurement, compound 4: no gap at the digits printed; the range from low to high includes it.
By their numbers in the HEL assay, from the lowest: compounds 1, 2, 3 and 4 (each within the scatter of the next).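

In the HEL assay the flat picture now extends to a group carrying hydrogen-bond acceptors on the carbon with a double bond to nitrogen, with no change at the digits printed from compound 3 to compound 4 (within the scatter) and no change at the digits printed from compound 2 to compound 4 (within the scatter) and no change at the digits printed from compound 1 to compound 4 (within the scatter) in this series. In a physicochemical assay for lipophilicity, measured as octanol-water partition (on this read-out higher numbers stand for higher lipophilicity and lower numbers for lower lipophilicity), compound 3 gives 3.61 and compound 4 gives 3.37, two values within the scatter of each other. Nothing available explains the flat cytotoxicity read-out.

Open, as far as these compounds go, is whether an amine or a carboxylic acid on this aromatic group would move the read-out. Also open, from the compounds shown here alone, is whether any change elsewhere in the shared core would do so.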